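The source may hold more compounds than are shown below. What is called first, only, known or untested is meant among the compounds shown, and "the series" means these compounds.

In an assay on HEK293 cells for negative allosteric modulation of metabotropic glutamate receptor 5 (Homo sapiens), read by FLIPR, with a stated time of 1 h (on this read-out lower numbers stand for stronger inhibition and higher numbers for weaker inhibition), compound 1 `O=C1NCCc2nc(C#Cc3cccc(F)c3)sc21` gives only a limit, > 10000 nM, not a number. Compound 2 `CC1CC1C(=O)N1CCc2nc(C#Cc3ccccc3)sc2C1` likewise gives only a limit in this assay, > 10000 nM. Both results sit at the limit of > 10000 nM in this assay, at which 2 of the 2 values shown sit, so compound 2 stands at the edge of what this assay can read, with no number of its own. Compound 3 `O=C(N1CCCC1)N1CCc2nc(C#Cc3ccccc3)sc2C1` differs from compound 2 by pyrrolidin-1-yl in place of 2-methylcyclopropyl on a carbonyl carbon. Going by the values given here, no measured step covers this change, so the step is expected to stay within the scatter, and a step that the limit leaves unreadable from compound 2 to compound 3 is estimated as essentially no shift. Compound 3 is therefore expected to give about 12000 nM, somewhere between 3000 nM and 50000 nM, most likely again only a limit.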

Compound 3, half-maximal inhibitory concentration: > 10000 nM
Compound 3: a limit, no number; the forecaster's own chance of this, stated with the estimate: 70%; the middle value is on the limit's open side.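

Compound 2 and compound 3 each give only a limit, not a number, so no step between them can be read: the limit of > 10000 nM in this assay, at which 3 of the 3 values shown sit.

The compounds shown leave open which change to the shared core, if any, would give a real number instead of a limit.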